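Moving from a chloro-bearing urea to a methyl-bearing one

This account rests on a few compounds, and the source may have more. Where it says the series, first, only, none or still open, it means among the compounds named here.

Measured so far:
- compound 1, `CCc1nc2ccccc2c(=O)n1NC(=O)Nc1ccc([N+](=O)[O-])cc1`: 41%
- compound 2, `O=C(Nc1ccc(Cl)cc1)Nn1c(-c2ccccc2)nc2ccccc2c1=O`: 55%
- compound 3, `CCc1nc2ccccc2c(=O)n1NC(=O)Nc1ccc(Cl)cc1`: 52%

All three numbers come from a functional assay on the whole organism (strain albino) with Mus musculus as the target, at a dose of 100 mg/kg by the intraperitoneal route (on this read-out lower numbers stand for less inhibition and higher numbers for more inhibition at the one dose given (going by the name of the read-out)), a test in a living animal rather than on an isolated protein. Compound 3 stands second highest of the three: its gap to compound 2 is within the scatter, so the two cannot be ordered, while its gap to compound 1 is beyond it. The two measured steps leading to compound 3 are a number 11 percentage points higher from compound 1 to compound 3 (beyond the scatter) and a number 3 percentage points lower from compound 2 to compound 3 (within the scatter), so a change on the phenyl ring of the urea moved the number modestly, and a change on the shared core hardly at all.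

Compound 4, `CCc1nc2ccccc2c(=O)n1NC(=O)Nc1ccccc1C`, differs from compound 3 in one place: 2-methylphenyl in place of 4-chlorophenyl on an amide-type nitrogen. Among the compounds with values here, no measured step shows this exact exchange. The closest guide is the step on that same ring from compound 1 to compound 3, which was modest, and that argues for a step in this assay of similar or smaller size, most likely within the scatter or slightly downward. Compound 4 is therefore expected at about 45%, between 30% and 60%, which means an expected step of a number 7 percentage points lower from compound 3 to compound 4 (within the scatter).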

Compound 4, a percentage reported as inhibition, in the whole organism at one dose (the size of the read-out at that dose, not a potency): 54%
Compound 4: middle estimate off by 9 percentage points, on the low side; the measured number falls inside the stated range.
By their numbers in this assay, from the lowest: compound 1; then compounds 3, 4 and 2 (each within the scatter of the next).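

Replacing 4-chlorophenyl with 2-methylphenyl on the amide-type nitrogen gives a number 2 percentage points higher from compound 3 to compound 4 (within the scatter) in this assay, so this exchange, which changes both the group on the ring and its number in the name, leaves no readable mark on the result at this one dose. The earlier step on this ring, a number 11 percentage points higher from compound 1 to compound 3 (beyond the scatter), was beyond the scatter, so the ring does not accept every exchange equally, and the new step shows that at least these two substituted rings cannot be told apart. Nothing available explains why these two rings read alike.

On these data alone, it remains open whether a ring carrying an amine or a carboxylic acid would read like compound 3 and compound 4. As far as these compounds go, it is also open whether 2-methylphenyl would behave the same way with phenyl in place of ethyl, as on the core of compound 2.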